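The source may hold more compounds than are shown below. What is called first, only, known or untested is meant among the compounds shown, and "the series" means these compounds.

Of the compounds shown here, two built on the same core have numbers so far. In a functional assay on PC-3 cells (Homo sapiens) for antiproliferative activity, read by MTT assay, with a stated time of 72 h (on this read-out lower numbers stand for stronger inhibition and higher numbers for weaker inhibition), compound 1 (`CCn1c(C(=O)NCCC(=O)O)ccc1C(CC)(CC)c1ccc(C#CC(O)(CC)CC)c(C)c1`) gives 5130 nM, while compound 2 (`CCn1cc(C(CC)(CC)c2ccc(C#CC(O)(CC)CC)c(C)c2)cc1C(=O)NCC(=O)OC`) gives 17500 nM. Compound 2 therefore has the higher of the two numbers and is the weaker inhibitor, and the gap between them lies beyond the usual scatter of repeated measurements.

Compound 3 (`CCCCC(=O)c1cc(C(CC)(CC)c2ccc(C#CC(O)(CC)CC)c(C)c2)cn1CC`) departs from compound 2 at a single place: butyl in place of ((methoxycarbonyl)methyl)amino on a carbonyl carbon. Among the compounds with values here, the two measured compounds differ in more than one place, so no measured single-change step is available to size this one. The only reference point for a stronger result in this assay is compound 1 at 5130 nM, which suggests that the number could fall but gives little support for a large move. A moderate change toward stronger inhibition is therefore expected, with a real chance that it stays within the scatter, and the expected move is a 1.9-fold lower number from compound 2 to compound 3 (0.29 log units; within the scatter). For compound 3 the estimated value is 9000 nM, with an expected range from 2500 nM to 30000 nM.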

Compound 3, half-maximal inhibitory concentration: 48100 nM
Estimate against measurement, compound 3: 5.3-fold (0.73 log units) below, outside the stated range (above it).
By their numbers in this assay, from the lowest: compound 1; then compound 2; then compound 3.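

In this assay, within the data shown here, butyl in place of ((methoxycarbonyl)methyl)amino on a carbonyl carbon gives a 2.7-fold higher number from compound 2 to compound 3 (0.44 log units; beyond the scatter), the first single-change step in this set. It shows that the number responds to the group at this place and that this exchange moves it toward weaker inhibition, by a modest step beyond the scatter. The butyl group carries no hydrogen-bond donors or acceptors and the group that leaves carries both, but several things change together in this one step, and nothing measured here bears on why the inhibition weakens.

The compounds shown leave open whether the loss belongs to the absence of the nitrogen, the absence of the ester or the all-carbon chain itself, since no compound separates these parts of the change. On these data alone, it also remains open how the number would move with a dimethylamino group on the same carbonyl carbon, or with a hexyl chain in place of butyl, which would show whether chain length matters at this place.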